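The source may hold more compounds than are shown below. What is called first, only, known or untested is meant among the compounds shown, and "the series" means these compounds.

Compounds 1, 2 and 3 share one core and differ only in the group on one aromatic carbon. Compound 1 `Nc1ccc(-c2cc(=O)c3c(N)c(F)c(O)c(F)c3o2)cc1F` carries a hydroxy there; in a functional assay on MCF7 cells (Homo sapiens) for cytotoxicity, read by neutral red uptake, with a stated time of 3 days (on this read-out lower numbers stand for stronger inhibition and higher numbers for weaker inhibition), compound 1 gives a limit, > 10000 nM. Compound 2 `CN(C)c1c(F)c(N)c2c(=O)cc(-c3ccc(N)c(F)c3)oc2c1F` carries a dimethylamino and in this assay gives 39 nM. Compound 3 `CCOC(=O)c1c(F)c(N)c2c(=O)cc(-c3ccc(N)c(F)c3)oc2c1F` carries an ethoxycarbonyl and gives 1400 nM, the highest of the two measured numbers, with a 36-fold higher number from compound 2 to compound 3 (1.56 log units; beyond the scatter). Compound 4 `Nc1ccc(-c2cc(=O)c3c(N)c(F)c(C(=O)O)c(F)c3o2)cc1F` differs from compound 3 by hydrogen in place of ethyl on an oxygen next to a carbonyl group. Within the data shown here, no measured step covers this exact change; the nearest ones, an at least 7.1-fold lower number from compound 1 to compound 3 (0.85 log units; beyond the scatter) and a 36-fold higher number from compound 2 to compound 3 (1.56 log units; beyond the scatter), show that the group on this carbon shifts the number strongly. Compound 4 is therefore expected to move upward, by a 3.6-fold higher number from compound 3 to compound 4 (0.55 log units; beyond the scatter). Compound 4 is estimated at 5000 nM, with a range from 1000 nM to 20000 nM.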

Compound 4, half-maximal inhibitory concentration: > 10000 nM
Compound 4 ended at the assay's limit; the forecaster's own chance of this, stated with the estimate: 40%; middle value at least 2.0-fold (0.30 log units) away from the limit.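

Swapping ethyl for hydrogen on this oxygen weakens the result in this assay, with an at least 7.1-fold higher number from compound 3 to compound 4 (0.85 log units; beyond the scatter), so at this carbon carboxy does not stand in for ethoxycarbonyl. Carboxy in place of dimethylamino gives an at least 250-fold higher number from compound 2 to compound 4 (2.40 log units; beyond the scatter), which widens the spread seen on this one carbon. The step between compound 1 and compound 4 cannot be read: the limit of > 10000 nM in this assay, at which 2 of the 4 values shown sit.

As far as these compounds go, what a methyl ester or a primary amide would give on this carbon stays open. So does whether a longer alkyl chain on the ester oxygen would move the number further.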